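Aryl replacement at the five-membered ring: compound 3

The source may hold more compounds than are shown below. What is called first, only, known or untested is meant among the compounds shown, and "the series" means these compounds.

Within the data shown here, compound 2 `Nc1ncnn2c([C@@H]3O[C@H](CO)[C@@H](O)[C@H]3O)cc(-c3ccc(F)cc3F)c12` holds the highest of the two numbers so far in a functional assay on Z-138 cells (Homo sapiens) for antiproliferative activity, with a stated time of 72 h (a lower number here means a stronger inhibitor, a higher number a weaker inhibitor), where compound 2 gives 59100 nM; the nearest neighbour is compound 1 `CCCCC#Cc1cc([C@@H]2O[C@H](CO)[C@@H](O)[C@H]2O)n2ncnc(N)c12`, for which compound 1 gives 200 nM. Among the measured compounds shown here, the only measured step, a 300-fold higher number from compound 1 to compound 2 (2.47 log units; beyond the scatter), is large and comes from 2,4-difluorophenyl in place of hex-1-yn-1-yl on an aromatic carbon.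

Compound 3 `Cc1ccccc1-c1cc([C@@H]2O[C@H](CO)[C@@H](O)[C@H]2O)n2ncnc(N)c12` differs from compound 2 as follows: 2-methylphenyl in place of 2,4-difluorophenyl on an aromatic carbon. For the measured compounds named here, both groups are a single six-membered aromatic ring of carbon only attached at the same aromatic carbon, so the step from compound 1 to compound 2 bears on it only indirectly: it shows that a six-membered aromatic ring of carbon only at this position gives a far higher number than hex-1-yn-1-yl, but no measured step compares one such ring with another. The expected step of a 1.7-fold lower number from compound 2 to compound 3 (0.23 log units; within the scatter) is therefore small, with no firm direction, and a wide range is kept because nothing measured separates 2-methylphenyl from 2,4-difluorophenyl here. Compound 3 is estimated at 35000 nM, between 6000 nM and 200000 nM.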

Compound 3, half-maximal inhibitory concentration: 66000 nM
The estimate for compound 3 lay 1.9-fold (0.28 log units) below the measured number, and the stated range covers the measured number.
By their numbers in this assay, from the lowest: compound 1; then compounds 2 and 3 (each within the scatter of the next).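

In this assay, 2-methylphenyl in place of 2,4-difluorophenyl on this aromatic carbon of the five-membered ring gives a 1.1-fold higher number from compound 2 to compound 3 (0.05 log units; within the scatter), so these two substitution patterns on a six-membered aromatic ring of carbon only cannot be told apart here. The large penalty relative to hex-1-yn-1-yl also recurs with this second ring, at a 330-fold higher number from compound 1 to compound 3 (2.52 log units; beyond the scatter), so across the two aryl groups shown it is not tied to the two fluorines of compound 2. Nothing available accounts for the result or for the gap between the aryl groups and the alkyne chain.

Going by these compounds, it remains open whether the value of compound 1, 200 nM, depends on the triple bond or on the length of the chain, which a saturated hexyl group or a shorter prop-1-yn-1-yl group at the same carbon would address. It is also open whether any ring can be accommodated at this carbon, as only two substituted phenyl groups are shown, and a pyridine ring or a phenyl ring bearing an amine or a carboxylic acid would extend the comparison.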